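Carbonate chain variation and half-life in the series

The source may hold more compounds than are shown below. What is called first, only, known or untested is meant among the compounds shown, and "the series" means these compounds.

Compound 1 `COC(=O)OCC(CO)CCn1cnc2cnc(N)nc21` — 552 h
Compound 2 `CCCOC(=O)OCC(CO)CCn1cnc2cnc(N)nc21` — 696 h
Compound 3 `CC(C)OC(=O)OCC(CO)CCn1cnc2cnc(N)nc21` — 2110 h

In an ADME assay for pharmacokinetics, read by HPLC, at 37 degrees C, at pH 1.2 (on this read-out lower numbers stand for a shorter-lived compound and higher numbers for a longer-lived compound), compound 3 gives the highest of the three numbers, 2110 h; the steps up to it are a 3.0-fold higher number from compound 2 to compound 3 (0.48 log units; beyond the scatter) and a 3.8-fold higher number from compound 1 to compound 3 (0.58 log units; beyond the scatter), both beyond the scatter. The methyl and propyl carbonates sit together: a 1.3-fold higher number from compound 1 to compound 2 (0.10 log units; within the scatter), within the scatter, so no order between compound 1 and compound 2 is claimed.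

Compound 4 `CC(C)CCOC(=O)OCC(CO)CCn1cnc2cnc(N)nc21` carries the change (isopentyl in place of isopropyl on an oxygen next to a carbonyl group). Among the measured compounds shown here, the steps that bear on it are a 3.8-fold higher number from compound 1 to compound 3 (0.58 log units; beyond the scatter) and a 3.0-fold higher number from compound 2 to compound 3 (0.48 log units; beyond the scatter), where isopropyl raised the number by a modest amount over methyl and over propyl, while a 1.3-fold higher number from compound 1 to compound 2 (0.10 log units; within the scatter) shows methyl and propyl indistinguishable. Of the measured groups, propyl is the nearest relative of isopentyl. Compound 4 is therefore expected to fall back toward the propyl value, a step of a 2.3-fold lower number from compound 3 to compound 4 (0.37 log units; beyond the scatter), and is estimated at 900 h with a range of 400 h to 2200 h.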

Compound 4, half-life in the ADME assay: 576 h
Estimate against measurement, compound 4: 1.6-fold (0.19 log units) above; measured number inside the range.
By their numbers in the ADME assay, from the lowest: compounds 1, 4 and 2 (each within the scatter of the next); then compound 3.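

On the oxygen next to a carbonyl group, a branched chain as such does not carry the raised half-life: in the ADME assay isopentyl gives a 3.7-fold lower number from compound 3 to compound 4 (0.56 log units; beyond the scatter), so the high number stays with isopropyl alone among the groups shown. Compound 4 also joins the other two carbonates, with a 1.2-fold lower number from compound 2 to compound 4 (0.08 log units; within the scatter) and a 1.0-fold higher number from compound 1 to compound 4 (0.02 log units; within the scatter), both within the scatter, so methyl, propyl and isopentyl are not put in any order. In a physicochemical assay for solubility, read by spectrophotometry, at 20 degrees C (a higher number here means a more soluble compound, a lower number a less soluble compound), compound 3 gives 139000 ug/mL and compound 4 gives 5600 ug/mL, a 25-fold lower number from compound 3 to compound 4 (1.39 log units; beyond the scatter), a large step for this same change.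

Among the compounds shown here, whether the two read-outs move together across the series remains open, as only one pair carries both. From the compounds shown here alone, how a tert-butyl or cyclopentyl group, or a chain ending in an amine, would read at this oxygen also stays unknown.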